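The source may report more compounds than this note shows. Statements on the series, on what has been measured and on what is new or still open speak of the compounds shown alone.

Measured in a functional assay on K562 cells (Homo sapiens) for cytotoxicity, read by trypan blue exclusion, with a stated time of 96 h; on this read-out higher numbers stand for weaker inhibition and lower numbers for stronger inhibition:
Compound 1 `COC(=O)[C@H](C)Nc1cc(CS(=O)(=O)/C=C/c2c(OC)cc(OC)cc2OC)ccc1OC`: 200 nM
Compound 2 `COC(=O)C(C)(C)Nc1cc(CS(=O)(=O)/C=C/c2c(OC)cc(OC)cc2OC)ccc1OC`: 800 nM
Compound 3 `COc1cc(OC)c(/C=C/S(=O)(=O)Cc2ccc(OC)c(NCCC(=O)O)c2)c(OC)c1`: 5000 nM

Of the three, compound 3 stands highest at 5000 nM, which makes it the weakest inhibitor of the set. Compound 4 `COc1cc(OC)c(/C=C/S(=O)(=O)Cc2ccc(OC)c(NC(C(=O)O)c3ccc(F)cc3)c2)c(OC)c1` differs from it at one place, with carboxy(4-fluorophenyl)methyl in place of 2-carboxyethyl on a nitrogen on an aromatic ring.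

For the measured compounds named here, no measured step makes this exchange, and none introduces an aromatic ring into this group. The closest evidence is indirect. There is a 25-fold higher number from compound 1 to compound 3 (1.40 log units; beyond the scatter), a large step, and a 6.3-fold higher number from compound 2 to compound 3 (0.80 log units; beyond the scatter), a modest one. Both show that the branched groups of compounds 1 and 2 sit lower than 2-carboxyethyl, but those groups also carry methoxycarbonyl rather than carboxy, so the two features cannot be separated. There is also a 4.0-fold higher number from compound 1 to compound 2 (0.60 log units; beyond the scatter), a modest step, which shows that added bulk on the branched carbon can raise the number. Compound 4 shares the branching but keeps the carboxy group of compound 3, so only part of those steps should carry over.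

The expected change is modest and toward stronger inhibition, estimated as a 3.3-fold lower number from compound 3 to compound 4 (0.52 log units; beyond the scatter). For compound 4 the estimated value is 1500 nM, with an expected range of 300 nM to 6000 nM.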

Compound 4, half-maximal inhibitory concentration: 80 nM
Beside the measured number, compound 4's estimate is 19-fold (1.27 log units) above it; measured number below the stated range.
By their numbers in this assay, from the lowest: compound 4; then compound 1; then compound 2; then compound 3.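

In this assay, carboxy(4-fluorophenyl)methyl in place of 2-carboxyethyl on a nitrogen on an aromatic ring gives a 63-fold lower number from compound 3 to compound 4 (1.80 log units; beyond the scatter), which shows that this position accepts a group with a six-membered aromatic ring and that a carboxy group there can go with the lowest number of the four. For the compounds shown here, compound 3 was the only earlier compound with a free carboxy group and it had the highest number, yet the new acid also lies below both methyl esters, with a 10-fold lower number from compound 2 to compound 4 (1.00 log units; beyond the scatter) and a 2.5-fold lower number from compound 1 to compound 4 (0.40 log units; beyond the scatter), so a free carboxy group on this nitrogen substituent does not in itself set a high number. No measurement shown here accounts for the size of these steps.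

The compounds shown do not separate the aromatic ring from its fluorine, which a plain phenyl or a 4-chlorophenyl group in the same place would address. They also leave open how the methyl ester of the compound 4 group would compare with the acid, and whether the two mirror-image forms at the carbon carrying the ring would give the same number.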